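This account rests on a few compounds, and the source may have more. Where it says the series, first, only, none or still open, it means among the compounds named here.

Working notes on the series.

The shared core carries a variable aryl group on an aromatic nitrogen of the five-membered ring. Two members have been measured in a functional assay on the whole organism (strain Albino Wistar) for inhibition, with Rattus norvegicus as the target, read by paw edema, with stated times of 1 h and 3 h, at a dose of 10 mg/kg by the oral route; a lower number here means less inhibition, a higher number more inhibition at the dose given (going by the name of the read-out). Compound 1 `Clc1cccc(-n2cc(CSc3nc4ccccc4s3)nn2)c1` gives 35% in this assay. Compound 2 `O=[N+]([O-])c1ccc(-n2cc(CSc3nc4ccccc4s3)nn2)cc1` gives 75% in this assay. Of the two numbers, compound 1 stands lowest; the value of compound 2 lies beyond the scatter above it. Going by the values given here, no step between two measured compounds differing in one place is available, so the two values are only set side by side.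

Compound 3 `c1cncc(-n2cc(CSc3nc4ccccc4s3)nn2)c1` has not yet been measured in this assay. It differs from compound 1 as follows: pyridin-3-yl in place of 3-chlorophenyl on an aromatic nitrogen. Nothing measured within the series bears directly on this exchange. No step beyond the scatter is expected; the size of step expected is a number 10 percentage points higher from compound 1 to compound 3 (within the scatter), the direction upward but within the usual scatter. Compound 3 is therefore estimated at 45% in this assay, with a range from 25% to 65%.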

Compound 3, a percentage reported as inhibition, in the whole organism at one dose (the size of the read-out at that dose, not a potency): 64%
Compound 3: the middle estimate sits 19 percentage points below what was measured; the range from low to high includes it.
By their numbers in this assay, from the lowest: compound 1; then compound 3; then compound 2.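

Going by these compounds alone, at the place on an aromatic nitrogen of the five-membered ring, the exchange of 3-chlorophenyl for pyridin-3-yl gives the only single-place step so far in this assay: a number 29 percentage points higher from compound 1 to compound 3 (beyond the scatter). This shows that the read-out at the dose given responds to the group at this position, and that a six-membered aromatic ring with 1 hetero atom and 1 hydrogen-bond acceptor, carrying no chlorine, goes with more inhibition than the 3-chlorophenyl group. No measurement at hand explains the step, so the part played by the ring nitrogen cannot be told apart from that of the departing chlorine.

An unsubstituted phenyl group on the same nitrogen would separate those two parts of the exchange, and pyridin-2-yl and pyridin-4-yl would show whether the place of the ring nitrogen matters. Also open, on these data alone, is how the read-out behaves with an amine or a carboxylic acid on the aryl ring, and whether the step holds when the rest of the shared core is changed.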